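Aryl amine series: compound 3 to compound 4

This account rests on a few compounds, and the source may have more. Where it says the series, first, only, none or still open, it means among the compounds named here.

Measured compounds in a functional assay on HeLa cells (Homo sapiens) for inhibition, read by sulforhodamine B assay; a higher number here means a weaker inhibitor, a lower number a stronger inhibitor:
Compound 1, `CCOc1ccc(NC2=CC(=O)c3c(nc4n3[C@H]3OC[C@@H](O)[C@H]3OC4)C2=O)cc1`, gives 14400 nM.
Compound 2, `COc1ccccc1NC1=CC(=O)c2c(nc3n2[C@H]2OC[C@@H](O)[C@H]2OC3)C1=O`, gives 7460 nM.
Compound 3, `CCOc1ccccc1NC1=CC(=O)c2c(nc3n2[C@H]2OC[C@@H](O)[C@H]2OC3)C1=O`, gives 8300 nM.

Compound 3 stands second highest of the three numbers; the steps of a 1.1-fold higher number from compound 2 to compound 3 (0.05 log units; within the scatter) and a 1.7-fold lower number from compound 1 to compound 3 (0.24 log units; within the scatter) both lie within the scatter, so no order among the three can be read.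

The next compound, compound 4, `O=C1C(Nc2ccc(C(F)(F)F)cc2)=CC(=O)c2c1nc1n2[C@H]2OC[C@@H](O)[C@H]2OC1`, differs from compound 3 in one place: 4-(trifluoromethyl)phenyl in place of 2-ethoxyphenyl on an amine nitrogen. For the measured compounds named here, no measured step exchanges an alkoxy group for a trifluoromethyl, so none bears on it directly; the steps that move or shorten the alkoxy, a 1.9-fold lower number from compound 1 to compound 2 (0.29 log units; within the scatter) and a 1.7-fold lower number from compound 1 to compound 3 (0.24 log units; within the scatter), all stayed within the scatter. On that basis compound 4 is expected to sit close to compound 3, with the step of a 1.0-fold lower number from compound 3 to compound 4 (0.02 log units; within the scatter) estimated to stay within the scatter. Compound 4 is thus estimated at 8000 nM, in the range 3000 nM to 25000 nM.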

Compound 4, half-maximal inhibitory concentration: 8920 nM
Beside the measured number, compound 4's estimate is 1.1-fold (0.05 log units) below it; low and high end bracket the measured number.
By their numbers in this assay, from the lowest: compounds 2, 3, 4 and 1 (each within the scatter of the next).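

In this assay the amine nitrogen accepts 4-(trifluoromethyl)phenyl with every step staying within the scatter (a 1.1-fold higher number from compound 3 to compound 4 (0.03 log units; within the scatter)), (a 1.2-fold higher number from compound 2 to compound 4 (0.08 log units; within the scatter)) and (a 1.6-fold lower number from compound 1 to compound 4 (0.21 log units; within the scatter)). The earlier compounds shown here varied only alkoxy-substituted phenyl groups, whereas this entering group has no oxygen and no hydrogen-bond acceptor, yet it still cannot be separated from them. Nothing on hand explains this flat response.

Still open, from the compounds shown here alone, is whether any group at this nitrogen moves the number beyond the scatter. A phenyl carrying a carboxylic acid or a primary amine, or a saturated cyclohexyl in place of the aromatic ring, would test this.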